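This account rests on a few compounds, and the source may have more. Where it says the series, first, only, none or still open, it means among the compounds named here.

Compound 1 `COc1ccccc1-c1cccc(S(=O)(=O)N2CCC(N3CCC(C)CC3)CC2)c1` stands lowest of the three numbers in an ADME assay on S9 fraction from liver (Mus musculus, strain ICR/CD-1) for metabolic stability, read by LC-MS, using NADPH, with a stated time of 5 min, tested at 2 uM; on this read-out lower numbers stand for a shorter-lived compound and higher numbers for a longer-lived compound: compound 1 gives 0.25 h. Compound 2 `CC1CCN(C2CCN(S(=O)(=O)c3cccc(-c4ccc(F)cc4)c3)CC2)CC1` gives 1.28 h in this assay, and compound 3 `COc1ccccc1-c1ccc(S(=O)(=O)N2CCC(N3CCC(C)CC3)CC2)cc1` gives 4.82 h. Compound 4 `CC1CCN(C2CCN(S(=O)(=O)c3cccc(-c4ccc(Cl)cc4)c3)CC2)CC1` differs from compound 1 by 4-chlorophenyl in place of 2-methoxyphenyl on an aromatic carbon. For the measured compounds named here, one measured step bears on this change, the exchange of 2-methoxyphenyl for 4-fluorophenyl on the same aromatic carbon: a 5.1-fold higher number from compound 1 to compound 2 (0.71 log units; beyond the scatter). Chlorine in place of fluorine is the only remaining difference, and no measured pair separates the two. An upward step of comparable size is therefore expected for compound 4 because a 5.1-fold higher number from compound 1 to compound 2 (0.71 log units; beyond the scatter) went beyond the scatter: a 4.4-fold higher number from compound 1 to compound 4 (0.64 log units; beyond the scatter). Compound 4 is estimated at 1.1 h in this assay, with a range from 0.45 h to 2.8 h.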

Compound 4, half-life: 2.45 h
Beside the measured number, compound 4's estimate is 2.2-fold (0.35 log units) below it, within the range that was stated.
By their numbers in this assay, from the lowest: compound 1; then compounds 2, 4 and 3 (each within the scatter of the next, the first and the last beyond it).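

In this assay, 4-chlorophenyl in place of 2-methoxyphenyl on this aromatic carbon gives a larger measured step (a 9.8-fold higher number from compound 1 to compound 4 (0.99 log units; beyond the scatter)), so a second replacement of 2-methoxyphenyl now moves the number upward. Chloro in place of fluoro gives no separable change (a 1.9-fold higher number from compound 2 to compound 4 (0.28 log units; within the scatter)), so this assay does not distinguish the two halogens at this position. No measurement at hand explains either step. Still open, from the compounds shown here alone, is whether unsubstituted phenyl, 4-methoxyphenyl or pyridyl on this carbon would give numbers like those of compound 2 and compound 4. Nitrile or trifluoromethyl in place of chloro also remains open.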